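A few compounds are considered here, and "the series" means these few. Any claim that something is new, unique, unknown or untested is made for them only; others in the source may bear on it.

In a functional assay on MV4-11 cells (Homo sapiens) for inhibition, read by luminescence, with a stated time of 72 h (on this read-out higher numbers stand for weaker inhibition and lower numbers for stronger inhibition), compound 1 `CCN1C(=O)COc2c(CN3CCN(C(C)C)CC3)cc(Nc3ncc(F)c(-c4ccc(F)cc4OC)n3)cc21` gives 149 nM and compound 2 `CCN1C(=O)COc2c(CN3CCN(C(C)=O)CC3)cc(Nc3ncc(F)c(-c4ccc(F)cc4OC)n3)cc21` gives 17 nM, the lower of these two numbers. Compound 3 `CCN(CC)Cc1cc(Nc2ncc(F)c(-c3ccc(F)cc3OC)n2)cc2c1OCC(=O)N2CC` keeps the shared core of compound 2 but changes one group: diethylamino in place of 4-acetylpiperazin-1-yl on a saturated chain carbon bound to an aromatic carbon. For the measured compounds named here, the only measured step, an 8.8-fold lower number from compound 1 to compound 2 (0.94 log units; beyond the scatter), came from acetyl in place of isopropyl on an amine nitrogen in a ring, so changes in this part have moved the number, although no measured pair covers diethylamino. A moderately higher number is therefore expected, an estimated step of a 3.5-fold higher number from compound 2 to compound 3 (0.55 log units; beyond the scatter). For compound 3 the estimated value is 60 nM, with an expected range of 15 nM to 240 nM.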

Compound 3, half-maximal inhibitory concentration in the MV4-11 assay: 26 nM
Compound 3: the middle estimate sits 2.3-fold (0.36 log units) above what was measured; the range from low to high includes it.
By their numbers in the MV4-11 assay, from the lowest: compounds 2 and 3 (each within the scatter of the next); then compound 1.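

On the saturated chain carbon bound to an aromatic carbon, in the MV4-11 assay, where compound 1 gives 149 nM, compound 2 gives 17 nM and compound 3 gives 26 nM, an open diethylamino group with no ring can stand in for 4-acetylpiperazin-1-yl (a 1.5-fold higher number from compound 2 to compound 3 (0.18 log units; within the scatter)), while replacing 4-isopropylpiperazin-1-yl with it gives (a 5.7-fold lower number from compound 1 to compound 3 (0.76 log units; beyond the scatter)). In a physicochemical assay for solubility, read by HPLC, in phosphate buffer, measured as kinetic solubility, with a stated time of 24 h, at pH 7.4 (a lower number here means a less soluble compound, a higher number a more soluble compound), where compound 2 gives 6.9 ug/mL and compound 3 gives 3.9 ug/mL, the first of these changes gives (a 1.8-fold lower number from compound 2 to compound 3 (0.25 log units; within the scatter)). Nothing shown explains these results.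

Going by these compounds, whether a smaller amine such as dimethylamino, or a ring amine such as pyrrolidine or morpholine, would fit this position equally well stays open.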